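Shortening the hydroxyalkyl amide chain at the cytotoxicity ceiling

The source may report more compounds than this note shows. Statements on the series, on what has been measured and on what is new or still open speak of the compounds shown alone.

Compound 3 `CC(C)C[C@@H](CO)NC(=O)c1cnc2ccccc2c1Cl` carries a 1-(hydroxymethyl)-3-methylbutyl group on the amide nitrogen of the shared core. In an ADME assay on CCRF-CEM cells (Homo sapiens) for cytotoxicity (a lower number here means that less compound is tolerated, a higher number that more compound is tolerated), compound 3 returns no number but a limit, > 100 uM. Its two relatives give the same picture. Compound 1 `O=C(NCCCO)c1cnc2ccccc2c1Cl` returns in this assay a limit, > 100 uM. Compound 2 `C[C@@H](CO)NC(=O)c1cnc2ccccc2c1Cl` likewise returns a limit, > 100 uM. Accordingly a step that the two limits leave unreadable from compound 1 to compound 2, a step that the two limits leave unreadable from compound 1 to compound 3 and a step that the two limits leave unreadable from compound 2 to compound 3 cannot be sized, since every value involved rests at the limit of > 100 uM in this assay, at which 3 of the 3 values shown sit.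

Compound 4 `O=C(NCCO)c1cnc2ccccc2c1Cl` differs from compound 3 by hydrogen in place of isobutyl on a saturated chain carbon bound to an amide-type nitrogen and a saturated chain carbon. The nearest measured analogue of this change is a step that the two limits leave unreadable from compound 2 to compound 3, where an isopropyl entered on the same chain, but that step stays unreadable because both of its ends sit at the limit of > 100 uM in this assay, at which 3 of the 3 values shown sit. Among the compounds with values here, no measured step therefore argues for any movement in this assay, in either direction. Compound 4 is expected to remain at the ceiling as well, with a step that the limit leaves unreadable from compound 3 to compound 4 read as no step beyond the scatter. The estimate for compound 4 in this assay is 150 uM, within a range from 70 uM to 400 uM.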

Compound 4, half-maximal toxic concentration: > 100 uM
Compound 4: no number, only a limit; the forecaster's own chance of this, stated with the estimate: 85%; the middle value is on the limit's open side.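

In this assay compound 4 gives > 100 uM as a limit. Its steps from compound 1, compound 2 and compound 3 therefore cannot be read: the limit of > 100 uM in this assay, at which 4 of the 4 values shown sit. The compounds shown leave open whether any change on the amide chain moves the result in this assay at all.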